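The compounds below may be only part of what the source reports. "The series", "measured", "known", "first", "only" and "open" are said of these compounds alone.

The measured compounds in a functional assay on HT-29 cells (Homo sapiens) for inhibition, read by sulforhodamine B assay, with a stated time of 48 h; on this read-out lower numbers stand for stronger inhibition of growth and higher numbers for weaker inhibition of growth:

Compound 1, `CCOC(=O)C1=C(C)NC(=S)NC1c1ccc(O)c(O)c1`: 33.7 ug/mL
Compound 2, `CCOC(=O)C1=C(C)NC(=O)NC1c1ccc(O)c(O)c1`: 37.8 ug/mL
Compound 3, `CCOC(=O)C1=C(C)NC(=S)NC1c1ccc(OC)cc1`: 30.6 ug/mL

All three numbers sit close together; the gap from compound 1 to compound 3 and the gap from compound 1 to compound 2 both lie within the scatter of repeated measurements, so the three compounds are not distinguished by this assay.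

Compound 4, `CCOC(=O)C1=C(C)NC(=S)NC1c1ccc(O)c(OC)c1`, has not yet been measured. It differs from compound 1 in one place:

methyl in place of hydrogen on an oxygen on an aromatic ring

Cut one bond further out, the change reads hydroxy to methoxy. Going by the values given here, no measured pair in this set isolates that change, so there is no step to lean on directly. What the set does show is that compound 3, which also carries a methoxy on its aromatic ring, gives a number no different from compound 1 beyond the scatter. On that basis compound 4 is expected to give a value close to compound 1, with a step of a 1.0-fold lower number from compound 1 to compound 4 (0.01 log units; within the scatter) that does not exceed the scatter. The estimate for compound 4 in this assay is 33 ug/mL, with a range from 16 ug/mL to 68 ug/mL.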

Compound 4, concentration for 50% growth inhibition: 34.9 ug/mL
Compound 4: middle estimate off by 1.1-fold (0.02 log units), on the low side, within the range that was stated.
By their numbers in this assay, from the lowest: compounds 3, 1, 4 and 2 (each within the scatter of the next).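

In this assay, methyl in place of hydrogen on an oxygen on an aromatic ring gives a 1.0-fold higher number from compound 1 to compound 4 (0.02 log units; within the scatter), so the hydroxy to methoxy change now stands as a direct pair rather than being inferred from a compound that differs in more than one place. At this position, the hydroxy is therefore not needed to keep the number of compound 1, since compound 4, with a methoxy there, cannot be told apart from it in this read-out. Nothing measured here explains this result.

From the compounds shown here alone, it remains open whether a longer chain on this oxygen, such as ethoxy or benzyloxy, would also stay within the scatter of compound 1. The same question holds for an amine or a carboxylic acid in place of the hydroxy at this position.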